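Swapping a Furan for a Bromophenyl on the Core

The source may report more compounds than this note shows. Statements on the series, on what has been measured and on what is new or still open speak of the compounds shown alone.

In a functional assay on ECa-109 cells (Homo sapiens) for antiproliferative activity, read by MTT assay, with a stated time of 72 h (a lower number here means a stronger inhibitor, a higher number a weaker inhibitor), compound 1 `CCCSc1nc(N/N=C(\C)c2ccccc2O)c2nnn(Cc3ccco3)c2n1` gives 5760 nM, the lowest of the three numbers measured here. Compound 3 `CCCSc1nc(N/N=C/c2ccc([N+](=O)[O-])cc2)c2nnn(Cc3ccccc3)c2n1`, with 6640 nM, sits within the scatter of compound 1, so the two cannot be told apart on these numbers. Within the data shown here, compound 2 `CCCSc1nc(N/N=C/c2ccc(N(C)C)cc2)c2nnn(Cc3ccccc3)c2n1`, with 20000 nM, lies furthest from compound 1; the only measured step that changes one place is a 3.0-fold lower number from compound 2 to compound 3 (0.48 log units; beyond the scatter). Compound 4 `CCCSc1nc(N/N=C(\C)c2ccccc2O)c2nnn(Cc3ccc(Br)cc3)c2n1` has not yet been measured. It differs from compound 1 in one place: 4-bromophenyl in place of furan-2-yl on a saturated chain carbon bound to an aromatic nitrogen. Among the measured compounds shown here, the one measured step, from compound 2 to compound 3, alters a group on another part of the shared core, and no measured pair shows what exchanging the group on the saturated chain carbon bound to the aromatic nitrogen does. With nothing comparable to lean on, the expectation for compound 4 is a number close to that of compound 1, with no step beyond the scatter, which as an estimate means a 1.0-fold lower number from compound 1 to compound 4 (0.02 log units; within the scatter). Compound 4 is therefore estimated at 5500 nM, with a range from 2000 nM to 16000 nM.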

Compound 4, half-maximal inhibitory concentration: 36100 nM
Compound 4: middle estimate off by 6.6-fold (0.82 log units), on the low side; measured number outside the range, above it.
By their numbers in this assay, from the lowest: compounds 1 and 3 (each within the scatter of the next); then compounds 2 and 4 (each within the scatter of the next).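

The group on the saturated chain carbon bound to an aromatic nitrogen clearly matters: in this assay, 4-bromophenyl in place of furan-2-yl gives a 6.3-fold higher number from compound 1 to compound 4 (0.80 log units; beyond the scatter). Among these compounds, the earlier compounds showed a change only on another part of the shared core, so this is the first measured sign that the position is sensitive to what it carries, and here the exchange goes towards a weaker inhibitor. No measurement shown here explains why the number rises.

This single exchange alters several things at once: the five-membered ring becomes a six-membered one, the ring oxygen leaves and a bromine enters, so the step cannot say which of these changes counts. Compounds 2 and 3 carry an unsubstituted phenyl at this place but differ from compound 1 and compound 4 elsewhere as well, which leaves open how that group would read on this core, and how a thiophen-2-yl or a 4-fluorophenyl group would compare.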